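Replacing 4-methylphenyl in compound 3

A few compounds are considered here, and "the series" means these few. Any claim that something is new, unique, unknown or untested is made for them only; others in the source may bear on it.

In a physicochemical assay for permeability, using PAMPA (on this read-out lower numbers stand for lower permeability and higher numbers for higher permeability), compound 1 `Cc1oc(-c2ccc(Cl)cc2)nc1CN1CCC(C(=O)NCCCN2C[C@H](C)C[C@H](C)C2)CC1` reports only a limit of > 635 10^-6 cm/s and no exact number. Compound 2 `Cc1oc(-c2ccc(Cl)c(Cl)c2)nc1CN1CCC(C(=O)NCCCN2C[C@H](C)C[C@H](C)C2)CC1` gives 522 10^-6 cm/s as its reading. Compound 3 `Cc1ccc(-c2nc(CN3CCC(C(=O)NCCCN4C[C@H](C)C[C@H](C)C4)CC3)c(C)o2)cc1` gives 274 10^-6 cm/s as its reading. Two steps reach it: a 1.9-fold lower number from compound 2 to compound 3 (0.28 log units; within the scatter) and an at least 2.3-fold lower number from compound 1 to compound 3 (0.36 log units; beyond the scatter), both exchanging only chloro and methyl groups. Compound 4 `COc1cccc(C)c1-c1nc(CN2CCC(C(=O)NCCCN3C[C@H](C)C[C@H](C)C3)CC2)c(C)o1` carries 2-methoxy-6-methylphenyl in place of 4-methylphenyl on an aromatic carbon on an aromatic carbon of the shared core. Among the measured compounds shown here, no measured step brings in a methoxy group, so compound 3 at 274 10^-6 cm/s remains the best guide and no step beyond the scatter is expected. The expected change is a 1.1-fold lower number from compound 3 to compound 4 (0.06 log units; within the scatter) in this estimate. In this assay the estimated value for compound 4 is 240 10^-6 cm/s with an expected range of 100 10^-6 cm/s to 550 10^-6 cm/s for this measurement.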

Compound 4, apparent permeability: 198 10^-6 cm/s
Beside the measured number, compound 4's estimate is 1.2-fold (0.08 log units) above it; low and high end bracket the measured number.
By their numbers in this assay, from the lowest: compounds 4, 3 and 2 (each within the scatter of the next, the first and the last beyond it). At a limit, above all of these: compound 1.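

In this assay, putting 2-methoxy-6-methylphenyl on this aromatic carbon brings in a methoxy group and gives a 1.4-fold lower number from compound 3 to compound 4 (0.14 log units; within the scatter), so this larger group reads much like 4-methylphenyl. Measured against 3,4-dichlorophenyl, the same group gives a 2.6-fold lower number from compound 2 to compound 4 (0.42 log units; beyond the scatter). Against 4-chlorophenyl the result is an at least 3.2-fold lower number from compound 1 to compound 4 (0.50 log units; beyond the scatter), which is only a floor set by the limit for compound 1: the limit of > 635 10^-6 cm/s in this assay, at which 1 of the 4 values shown sits.

The compounds shown leave open how much of these steps belongs to the methoxy group and how much to the methyl group. On these data alone, how an amine or a carboxylic acid at this position would read in this assay also remains open.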